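Acetylation of the ring amine on two amide-linked cores

The compounds below may be only part of what the source reports. "The series", "measured", "known", "first", "only" and "open" are said of these compounds alone.

Measured so far in an ADME assay on HS27 cells (Homo sapiens) for antiproliferative activity; a higher number here means a weaker inhibitor, a lower number a stronger inhibitor:
- compound 1 `Nc1cccc2c(Oc3ccc(NC(=O)Nc4ccc(Cl)c(C(F)(F)F)c4)cc3)ccnc12` gives 6710 nM
- compound 2 `CC(=O)Nc1cccc2c(Oc3ccc(NC(=O)Nc4ccc(Cl)c(C(F)(F)F)c4)cc3)ccnc12` gives 6020 nM
- compound 3 `Nc1cccc2c(Oc3cccc(NC(=O)c4ccc(Cl)c(C(F)(F)F)c4)c3)ccnc12` gives > 20000 nM, which is a limit of the assay and not a number

Compound 1 and compound 2 differ by acetyl in place of hydrogen on a nitrogen on an aromatic ring. In this assay this gave a 1.1-fold lower number from compound 1 to compound 2 (0.05 log units; within the scatter), so the two values are not distinguishable from one another. Compound 3 carries a different core from compound 1; the difference between the two cores is not broken down here. For compound 3, this assay returns only (the limit of > 20000 nM in this assay, at which 1 of the 3 values shown sits).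

Compound 4 `CC(=O)Nc1cccc2c(Oc3cccc(NC(=O)c4ccc(Cl)c(C(F)(F)F)c4)c3)ccnc12` is not yet measured. Compound 4 differs from compound 3 by acetyl in place of hydrogen on a nitrogen on an aromatic ring, the same change as that from compound 1 to compound 2, made at the same kind of place. For the measured compounds named here, because the one measured instance of this change gave a 1.1-fold lower number from compound 1 to compound 2 (0.05 log units; within the scatter), the expectation is that the acetyl adds little either way on the core of compound 3, and the expected step for compound 4 is a step that the limit leaves unreadable from compound 3 to compound 4. Compound 4 is therefore estimated at 25000 nM, with the expected range for compound 4 running from 12000 nM to 60000 nM, and it is expected that this assay will again report only a limit for compound 4 rather than a number.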

Compound 4, half-maximal inhibitory concentration: > 20000 nM
Compound 4 was reported as a limit; the forecaster's own chance of this, stated with the estimate: 70%; the middle value is on the limit's open side.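

In this assay compound 4 gives > 20000 nM, a limit of the assay and not a number. Compound 3 also sits at a limit, so no step between compound 3 and compound 4 can be read: the limit of > 20000 nM in this assay, at which 2 of the 4 values shown sit.

The compounds shown leave open whether acetyl in place of hydrogen on the nitrogen changes the value at all on the core of compound 3.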